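A few compounds are considered here, and "the series" means these few. Any claim that something is new, unique, unknown or untested is made for them only; others in the source may bear on it.

Measured in a functional assay on Jurkat cells (Homo sapiens); a higher number here means a weaker inhibitor, a lower number a stronger inhibitor:
- compound 1 `CC(C)[C@H](NC(=O)COc1cccc2ccccc12)C(=O)N[C@@H](CC(=O)O)C(=O)COc1ccc2ccccc2c1`: > 100000 nM (a limit)
- compound 2 `CC(C)[C@H](NC(=O)COc1cccc2ccccc12)C(=O)N[C@@H](CC(=O)O)C(=O)COc1ccc(OC(F)(F)F)cc1`: 29100 nM
- compound 3 `CC(C)[C@H](NC(=O)COc1cccc2ccccc12)C(=O)N[C@@H](CC(=O)O)C(=O)COc1ccc(F)cc1`: > 100000 nM (a limit)

Compound 3 stands at the limit of > 100000 nM in this assay, at which 2 of the 3 values shown sit; this is a limit and not a number. Compound 4 `CC(C)[C@H](NC(=O)COc1cccc2ccccc12)C(=O)N[C@@H](CC(=O)O)C(=O)COc1c(F)ccc(F)c1F` differs from it in one place: 2,3,6-trifluorophenyl in place of 4-fluorophenyl on an oxygen on a saturated carbon. Two measured steps change the group at this same place. One is an at least 3.4-fold lower number from compound 1 to compound 2 (0.53 log units; beyond the scatter), and the other is an at least 3.4-fold higher number from compound 2 to compound 3 (0.53 log units; beyond the scatter). Both lie beyond the scatter, so this group can clearly move the number. Among the measured compounds shown here, compound 2 is the only measured compound to give a number, and its group carries several fluorines. Compound 3 goes against any simple fluorine pattern, as it also carries fluorine yet sits at the limit, so the expectation is a loose one. A lower number is expected, by a step at least as large as those two. The expected step is an at least 12-fold lower number from compound 3 to compound 4 (1.09 log units; beyond the scatter). For compound 4 the estimated value is 8000 nM, with an expected range of 500 nM to 100000 nM.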

Compound 4, half-maximal inhibitory concentration: 1200 nM
For compound 4 the middle estimate is 6.7-fold (0.82 log units) above the measured one, within the range that was stated.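

The 2,3,6-trifluorophenyl group gives an at least 83-fold lower number from compound 3 to compound 4 (1.92 log units; beyond the scatter) in this assay, so fluorine on this ring can matter greatly, although the single fluorine of 4-fluorophenyl alone gives no readable value. Compared with the 4-(trifluoromethoxy)phenyl group, it gives a 24-fold lower number from compound 2 to compound 4 (1.38 log units; beyond the scatter), which makes compound 4 the strongest inhibitor of the four and shows that this position can improve well beyond what compound 2 first suggested. Replacing naphthalen-2-yl gives an at least 83-fold lower number from compound 1 to compound 4 (1.92 log units; beyond the scatter), and this step, like the one from the 4-fluorophenyl compound, is only a bound, as compound 1 and compound 3 each sit at a limit: the limit of > 100000 nM in this assay, at which 2 of the 4 values shown sit.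

Whether the gain needs all three fluorines remains open, as no compound shown carries two on this ring. From the compounds shown here alone, it is also open whether chlorine or a methoxy group could take the place of these fluorines.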